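Anilinohydrazone series: ethynyl for methyl on the imine aryl

The source may hold more compounds than are shown below. What is called first, only, known or untested is meant among the compounds shown, and "the series" means these compounds.

Measured so far in an assay on isolated protein for binding affinity to corticotropin-releasing factor receptor 1 (Homo sapiens); on this read-out higher numbers stand for weaker inhibition and lower numbers for stronger inhibition:
compound 1 `CC(=O)/C(=N\Nc1ccccc1Cl)Nc1cccc(Cl)c1` gives 417 nM; 417 nM (2 entries)
compound 2 `CC(=O)/C(=N\c1ccc(Cl)cc1)NNc1ccccc1C` gives 1830 nM
compound 3 `CC(=O)/C(=N\c1cccc(C)c1)NNc1ccccc1C` gives 526 nM

For the measured compounds named here, compound 3 holds the lowest of the two single numbers in this assay; compound 2 is the nearest, and the only one-place step in the set, a 3.5-fold lower number from compound 2 to compound 3 (0.54 log units; beyond the scatter), lies beyond the scatter. Going by the values given here, compound 1 carries two entries rather than one number and differs from compound 3 in more than one place, so no step is drawn to it.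

Compound 4 `C#Cc1cccc(/N=C(/NNc2ccccc2C)C(C)=O)c1` differs from compound 3 by ethynyl in place of methyl on an aromatic carbon, meta to a large group. Among the compounds with values here, no measured step changes a substituent at this position; the step from compound 2 to compound 3 swaps the whole aryl on the double-bonded nitrogen and bears on it only loosely. With nothing pointing either way, the change is expected to stay within the scatter, giving a 1.1-fold lower number from compound 3 to compound 4 (0.02 log units; within the scatter) for compound 4.

Compound 4 is therefore estimated at 500 nM in this assay, with a range of 200 nM to 1300 nM.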

Compound 4, inhibition constant: 62 nM
Compound 4: middle estimate off by 8.1-fold (0.91 log units), on the high side; measured number below the stated range.
By their numbers in this assay, from the lowest: compound 4; then compound 3; then compound 2.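

In this assay, for the compounds shown here, the substituent on this aromatic carbon, meta to a large group, carries real weight: ethynyl in place of methyl gives an 8.5-fold lower number from compound 3 to compound 4 (0.93 log units; beyond the scatter), the first step that changes a substituent here rather than swapping the whole aryl. The step comes with no hydrogen-bond donor or acceptor and no net charge on either group, so those counts do not separate compound 3 from compound 4. No measurement at hand gives a reason for the size of this step.

Going by these compounds, whether the lower number depends on the triple bond remains open, since an ethyl group, a nitrile or a longer alkyne chain at this position could be set against ethynyl. Also open, on these data alone, is whether ethynyl gives a similar step elsewhere on this ring.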